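The source may hold more compounds than are shown below. What is called first, only, known or untested is meant among the compounds shown, and "the series" means these compounds.

Working notes on the series in a functional assay on MCF7 cells (Homo sapiens) for inhibition, read by trypan blue exclusion, with a stated time of 3 days; on this read-out lower numbers stand for stronger inhibition and higher numbers for weaker inhibition: compound 1 (`COc1cc(C(=O)c2cn(-c3ccccc3)cc2-c2ccccc2F)cc(OC)c1OC`) gives 30 nM and compound 2 (`COc1cc(C(=O)c2cn(-c3ccccc3)cc2-c2cccc(N)c2)cc(OC)c1OC`) gives 28 nM. Compound 3 (`COc1cc(C(=O)c2cn(-c3cccc(C)c3)cc2-c2ccccc2)cc(OC)c1OC`) gives 120 nM, the highest number of the three and the weakest inhibitor among them.

The next structure is compound 4 (`COc1cc(C(=O)c2cn(-c3cccc(N)c3)cc2-c2ccccc2)cc(OC)c1OC`), with amino in place of methyl on an aromatic carbon, meta to a large group: amino in place of methyl on an aromatic carbon. Within the data shown here, no measured step makes this exchange. The nearest evidence is a 1.1-fold lower number from compound 1 to compound 2 (0.03 log units; within the scatter), which stays within the scatter, but there 3-aminophenyl replaces 2-fluorophenyl at a different place on the shared core, so it fixes no size for the present change. Among the measured compounds shown here, it shows only that compound 2, which carries the same 3-aminophenyl group, reaches 28 nM.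

A small step towards a lower number is therefore expected in this assay, possibly no larger than the scatter. The estimated step is a 1.7-fold lower number from compound 3 to compound 4 (0.23 log units; within the scatter). Compound 4 is expected at 70 nM, with an estimated range of 25 nM to 200 nM.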

Compound 4, half-maximal inhibitory concentration: 74 nM
For compound 4 the middle estimate is 1.1-fold (0.02 log units) below the measured one; the measured number falls inside the stated range.
By their numbers in this assay, from the lowest: compounds 2 and 1 (each within the scatter of the next); then compounds 4 and 3 (each within the scatter of the next).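

Among these compounds, this is the first direct reading of the exchange at this position, on an aromatic carbon, meta to a large group: in this assay the change from methyl to amino gives a 1.6-fold lower number from compound 3 to compound 4 (0.21 log units; within the scatter) and so stays within the usual scatter. Methyl carries no hydrogen-bond donor or acceptor and amino carries both, yet this pair shows no separation in the read-out at this place. No measurement available here accounts for the size of this step.

On these data alone, whether another group at this place, such as a hydroxyl, a carboxylic acid or a longer chain, would move the number beyond the scatter stays open. A single pair also leaves open whether amino in place of methyl would read the same on another aromatic carbon of the shared core.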